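This account rests on a few compounds, and the source may have more. Where it says the series, first, only, none or still open, it means among the compounds named here.

Compound 1, `COC(=O)[C@H](CCSC)NC(=O)c1ccc(NCc2cncn2Cc2ccc(C#N)cc2)cc1-c1ccccc1`: in a functional assay on NIH3T3 cells (Mus musculus) (on this read-out higher numbers stand for an effect only at larger amounts of compound and lower numbers for an effect already at smaller amounts), compound 1 gives > 10 uM, which is a limit of the assay and not a number.
Compound 2, `COC(=O)[C@H](CCSC)NC(=O)c1ccc(NCc2cncn2Cc2cccc([N+](=O)[O-])c2)cc1-c1ccccc1`: in this assay compound 2 gives > 10 uM, again only a limit.
Compound 3, `COC(=O)[C@H](CCSC)NC(=O)c1ccc(NCc2cncn2Cc2cccc(C#N)c2)cc1-c1ccccc1`: in this assay compound 3 gives > 10 uM, likewise a limit.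

Compound 3 therefore stands nowhere in particular among the numbers shown; it shares a limit with the two other measured compounds, and no ordering among the three can be read. The same holds for the pairwise comparisons: a step that the two limits leave unreadable from compound 1 to compound 2, a step that the two limits leave unreadable from compound 1 to compound 3 and a step that the two limits leave unreadable from compound 2 to compound 3 all remain unreadable, since every value involved is the limit of > 10 uM in this assay, at which 3 of the 3 values shown sit.

Compound 4, `COC(=O)[C@H](CCSC)NC(=O)c1ccc(NCc2cncn2Cc2ccc(C)cc2)cc1-c1ccccc1`, differs from compound 3 in one place: 4-methylphenyl in place of 3-cyanophenyl on a saturated chain carbon bound to an aromatic nitrogen. Going by the values given here, no measured step speaks to this exchange directly, and the three steps that exist give no readable size at all. Because every value on hand sits at the limit of > 10 uM in this assay, at which 3 of the 3 values shown sit, the only expectation the data support is that compound 4 will also fall at or beyond that limit. The estimated step is a step that the limit leaves unreadable from compound 3 to compound 4, understood as no change beyond the scatter. Compound 4 is thus expected to give 20 uM, with a range from 5 uM to 100 uM, most likely reported as a limit once more.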

Compound 4, concentration for half-maximal effect: > 10 uM
Compound 4: a limit, no number (the forecaster's own chance of this, stated with the estimate: 80%); the middle value lies beyond the limit too.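

In this assay compound 4 gives > 10 uM, which is a limit and not a number. Going by these compounds alone, no step between compound 4 and compound 1, compound 2 or compound 3 can be read: the limit of > 10 uM in this assay, at which 4 of the 4 values shown sit. The compounds shown leave open what concentration any of the four needs for half-maximal effect, and whether exchanging these groups changes it.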